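A few compounds are considered here, and "the series" means these few. Any claim that something is new, unique, unknown or untested is made for them only; others in the source may bear on it.

Compound 2, `CCCN(CCC)c1nc(O)c2c(-c3c(C)cc(C)cc3C)cn(C)c2n1`, stands at the edge of what can be read: in a functional assay on CHO cells for antagonist activity at corticotropin-releasing factor receptor 1 (Homo sapiens), read by cAMP accumulation (on this read-out lower numbers stand for stronger inhibition and higher numbers for weaker inhibition), compound 2 gives > 10000 nM, which is a limit of the assay rather than a number. For the measured compounds named here, compound 1, `CCCN(CCC)c1nc(Cl)c2c(-c3c(C)cc(C)cc3C)cn(C)c2n1`, is its only measured neighbour, and in this assay compound 1 gives > 10000 nM, again a limit. The step that the two limits leave unreadable from compound 1 to compound 2 therefore has no readable size, since both values sit at the limit of > 10000 nM in this assay, at which 2 of the 2 values shown sit. Compound 3, `CCCN(CCC)c1nc(OC)c2c(-c3c(C)cc(C)cc3C)cn(C)c2n1`, carries methyl in place of hydrogen on an oxygen on an aromatic ring. Going by the values given here, no measured step speaks to this change, so no direction is indicated. Compound 3 is expected to give 10000 nM, between 2500 nM and 40000 nM. The step of a number no higher from compound 2 to compound 3 (the limit leaves the size open) is accordingly expected to be nil.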

Compound 3, half-maximal inhibitory concentration: > 10000 nM
Compound 3 was reported as a limit; the forecaster's own chance of this, stated with the estimate: 70%; the middle value lies on the limit itself.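

No step can be read between compound 1, compound 2 and compound 3, since each result is a limit of the assay and not a number: the limit of > 10000 nM in this assay, at which 3 of the 3 values shown sit.

The compounds shown leave open how strongly each one inhibits, and whether chloro, hydroxy and methoxy on the aromatic carbon differ at all.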